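The compounds below may be only part of what the source reports. "The series", "measured", "known", "first", "only" and "open" are said of these compounds alone.

Three compounds share one core and differ only in the aryl group sitting on an oxygen on an aromatic ring. Compound 1 `COc1ccccc1Oc1cncc(C2=CC3CNCC(C2)C3)c1` carries 2-methoxyphenyl, compound 2 `Clc1ccc(Oc2cncc(C3=CC4CNCC(C3)C4)c2)cc1` carries 4-chlorophenyl, and compound 3 `Clc1cccc(Oc2cncc(C3=CC4CNCC(C3)C4)c2)c1` carries 3-chlorophenyl. In an in vitro assay on SH-EP1 cells for displacement of a labelled ligand from Neuronal acetylcholine receptor; alpha4/beta2 (Homo sapiens) (a lower number here means a stronger inhibitor, a higher number a weaker inhibitor), compound 1 gives 1 nM, compound 2 gives 1.9 nM, and compound 3 gives 1 nM. Compound 3 thus stands level with compound 1, the two together at the lowest of the three numbers, and the steps of a 1.9-fold higher number from compound 1 to compound 2 (0.28 log units; within the scatter), no change at the digits printed from compound 1 to compound 3 (within the scatter) and a 1.9-fold lower number from compound 2 to compound 3 (0.28 log units; within the scatter) all lie within the scatter.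

Compound 4 `Fc1ccc(Oc2cncc(C3=CC4CNCC(C3)C4)c2)cc1` has not yet been measured. Its change from compound 3 is 4-fluorophenyl in place of 3-chlorophenyl on an oxygen on an aromatic ring. Two kinds of measured step bear on it: the exchange of 4-chlorophenyl for 3-chlorophenyl, a 1.9-fold lower number from compound 2 to compound 3 (0.28 log units; within the scatter), and the exchange of 2-methoxyphenyl for either chlorophenyl. All were within the scatter, so no step beyond the scatter in this assay is expected for compound 4 in either direction. The swap of chlorine for fluorine has no measured precedent among these compounds. Compound 4 is therefore estimated at 1.6 nM, with a range from 0.5 nM to 5 nM, which means an expected step of a 1.6-fold higher number from compound 3 to compound 4 (0.20 log units; within the scatter).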

Compound 4, inhibition constant: 0.6 nM
For compound 4 the middle estimate is 2.7-fold (0.43 log units) above the measured one, and the stated range covers the measured number.
By their numbers in this assay, from the lowest: compounds 4, 1, 3 and 2 (each within the scatter of the next, the first and the last beyond it).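

Among these compounds, compound 4 gives the first measured precedent for fluoro in place of chloro on an aromatic carbon in this set: in this assay this change gives a step beyond the scatter, though a modest one (a 3.2-fold lower number from compound 2 to compound 4 (0.50 log units; beyond the scatter)). The other two steps stay within the scatter (a 1.7-fold lower number from compound 3 to compound 4 (0.22 log units; within the scatter); a 1.7-fold lower number from compound 1 to compound 4 (0.22 log units; within the scatter)), so at this oxygen 4-fluorophenyl cannot be told apart from 3-chlorophenyl or 2-methoxyphenyl, and only 4-chlorophenyl differs from it. Nothing available here explains the difference between the two halogens.

From the compounds shown here alone, this halogen exchange rests on a single pair of compounds, so it remains open whether it would recur on another aryl group. Also open, going by these compounds, is how the number would respond if an amine or a carboxylic acid were placed on the phenyl ring, or if a longer chain replaced that ring on the oxygen.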